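This account rests on a few compounds, and the source may have more. Where it says the series, first, only, none or still open, it means among the compounds named here.

Measured so far:

compound 1 `COc1ccc(-c2c(C#N)c(N)c(C#N)c(SC)c2-c2ccccc2)cc1`: 37.9%
compound 2 `COc1ccc(-c2c(C#N)c(N)c(C#N)c(SC)c2-c2ccc(OC)cc2)cc1`: 6.9%
compound 3 `Cc1c(-c2ccccc2)c(C#N)c(N)c(C#N)c1N1CCCCC1`: 4.7%

All three were tested in an assay on isolated protein for inhibition of glucose-6-phosphatase catalytic subunit 1 (Homo sapiens), tested at 100 uM; a higher number here means more inhibition at the concentration tested (going by the name of the read-out), a lower number less inhibition. Going by the values given here, the one single change that has been measured is methoxy in place of hydrogen on an aromatic carbon, which gave a number 31 percentage points lower from compound 1 to compound 2 (beyond the scatter). Compound 4 `COc1ccc(-c2c(C)c(N3CCCCC3)c(C#N)c(N)c2C#N)cc1` has not yet been measured in this assay; against compound 3 it carries the same change, (methoxy in place of hydrogen on an aromatic carbon). The difference between the core of compound 1 and the core of compound 3 is not broken down here, so the two cores are simply taken as different. Compound 3 gives 4.7%, a reading that leaves little room for a further drop. In this assay the expected step is a number 1.7 percentage points lower from compound 3 to compound 4 (within the scatter), much smaller than the earlier one, because compound 3 starts at 4.7%. Compound 4 is therefore estimated at 3%, with a range from 0% to 15%.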

Compound 4, a percentage reported as inhibition, at one concentration (the size of the read-out at that concentration, not a potency): 15.7%
For compound 4 the middle estimate is 12.7 percentage points below the measured one; measured number outside the range, above it.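

On the core of compound 3, methoxy in place of hydrogen gave a number 11 percentage points higher from compound 3 to compound 4 (beyond the scatter) in this assay. The same change therefore does not carry over from one core to the other with the same direction or size: the same change on two cores in this assay, a number 31 percentage points lower (beyond the scatter) from compound 1 to compound 2 and a number 11 percentage points higher (beyond the scatter) from compound 3 to compound 4, 42 percentage points apart, beyond the scatter of two such steps. Going by these compounds alone, this shows that, in this series, the outcome of the change depends on the core it is made on, but with only two cores, which differ in more than one place, it does not show which part of the core matters.

Also open, on these data alone, is how other groups in the methoxy position, such as an amine, a carboxylic acid or a longer chain like ethoxy, would read on either core. A pair of cores differing in only one place would help separate these effects.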